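From hydrogen to chloro: what to expect for compound 3

The compounds below may be only part of what the source reports. "The series", "measured", "known", "first", "only" and "open" are said of these compounds alone.

Measured compounds:
compound 1 `Nc1cccc(/C=C2\SC(=O)N(Cc3ccc(F)cc3)C2=O)c1`, 87000 nM
compound 2 `Nc1cccc(/C=C2\SC(=O)N(Cc3ccccc3)C2=O)c1`, > 250000 nM

In a functional assay on CCRF-CEM cells (Homo sapiens) for cytotoxicity, read by cell counting, with a stated time of 3 days (on this read-out lower numbers stand for stronger inhibition and higher numbers for weaker inhibition), compound 1 gives 87000 nM. Compound 2, which differs only in carrying hydrogen in place of fluoro on an aromatic carbon, reaches only the limit of this assay, > 250000 nM, so for compound 2 no number is known, only that it lies at the limit of > 250000 nM in this assay, at which 1 of the 2 values shown sits. Among the compounds with values here, that step, an at least 2.8-fold higher number from compound 1 to compound 2 (0.45 log units; beyond the scatter), is the sole measured comparison, and it shows the loss of the fluoro costing potency.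

Compound 3 `Nc1cccc(/C=C2\SC(=O)N(Cc3ccc(Cl)cc3)C2=O)c1` has not yet been measured. Compared with compound 2, the change is chloro in place of hydrogen on an aromatic carbon, para to a large group. Within the data shown here, since the only measured step placed a halogen at this spot above plain hydrogen, a chloro is expected to pull the number back down from the limit seen for compound 2, by about an at least 3.5-fold lower number from compound 2 to compound 3 (0.55 log units; beyond the scatter). The estimate for compound 3 in this assay is therefore 70000 nM, with a range from 20000 nM to 250000 nM.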

Compound 3, half-maximal inhibitory concentration: > 250000 nM
Compound 3: a limit, no number; the forecaster's own chance of this, stated with the estimate: 25%; middle value at least 3.5-fold (0.55 log units) away from the limit.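

Compound 3 reaches only a limit of the assay, not a number, so at this place on the ring, para to a large group, having a halogen is not enough to give a readable value. In this assay, exchanging fluoro for chloro gives an at least 2.8-fold higher number from compound 1 to compound 3 (0.45 log units; beyond the scatter), which means that among the compounds shown, the gain over plain hydrogen belongs to fluoro and does not extend to halogens in general. The step between compound 2 and compound 3 cannot be read, and hydrogen and chloro cannot be put in order here, because both compounds stop at the same ceiling: the limit of > 250000 nM in this assay, at which 2 of the 3 values shown sit.

On these data alone, how far compound 2 and compound 3 lie beyond that limit remains unknown, so chloro could still differ from hydrogen without this measurement showing it. Also open, as far as these compounds go, is whether fluoro is a lone exception or whether another small group at the same place, such as a methyl, a methoxy or an amine, would also bring the value back within range.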